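A few compounds are considered here, and "the series" means these few. Any claim that something is new, unique, unknown or untested is made for them only; others in the source may bear on it.

Compound 1 `Fc1cc(F)c2[nH]cc(-c3ccc4ccccc4n3)c2c1` and compound 3 `Fc1cc2c(-c3ccc4ccccc4n3)c[nH]c2c(F)c1F` share a core, and compound 3 carries one change: fluoro in place of hydrogen on an aromatic carbon. In an ADME assay on microsomes from liver (Homo sapiens) for metabolic stability, using NADPH, with a stated time of 40 min, tested at 2 uM (on this read-out lower numbers stand for a shorter-lived compound and higher numbers for a longer-lived compound), compound 1 gives 0.45 h, and that change brings a 1.8-fold lower number from compound 1 to compound 3 (0.26 log units; within the scatter). Compound 3 gives 0.25 h. Compound 2 `Cc1cccc2c(-c3ccc4ccccc4n3)c[nH]c12` has a different core; the difference between the two cores is not broken down here. In this assay compound 2 gives 0.35 h. Compound 4 `Cc1c(F)ccc2c(-c3ccc4ccccc4n3)c[nH]c12` has not been measured; compared with compound 2 it carries fluoro in place of hydrogen on an aromatic carbon. This is the same kind of change as that from compound 1 to compound 3, though there the fluoro sits ortho to two fluoro groups, while here it sits ortho to a methyl group. A step of similar size is expected, a 1.4-fold lower number from compound 2 to compound 4 (0.15 log units; within the scatter), because the earlier change gave only a 1.8-fold lower number from compound 1 to compound 3 (0.26 log units; within the scatter). Compound 4 is therefore estimated at 0.25 h, likely between 0.12 h and 0.5 h.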

Compound 4, half-life: 0.433 h
For compound 4 the middle estimate is 1.7-fold (0.24 log units) below the measured one; the range from low to high includes it.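

In this assay, fluoro in place of hydrogen on an aromatic carbon gives a 1.2-fold higher number from compound 2 to compound 4 (0.09 log units; within the scatter), so on this core the half-life stays within the usual scatter. Set beside the earlier step, the two cores do not clearly part: the same change on two cores in this assay, a 1.8-fold lower number (0.26 log units; within the scatter) from compound 1 to compound 3 and a 1.2-fold higher number (0.09 log units; within the scatter) from compound 2 to compound 4, 2.2-fold (0.35 log units) apart, within the scatter of two such steps This shows that the change carries across these two cores with no difference that can be told from scatter, but two small steps cannot show that it would behave alike on any further core.

The compounds shown leave open whether a different group on the same aromatic carbon, such as an amine or a methoxy group, would move the half-life beyond the scatter. They also leave open what a trifluoromethyl group would do there.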